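Imidazole for Furan: the Maximal Response of Compound 3

The source may hold more compounds than are shown below. What is called first, only, known or untested is meant among the compounds shown, and "the series" means these compounds.

Compound 1 `c1csc(-c2ccccc2OCC2=NCCN2)c1` — 101%
Compound 2 `c1ccc(-c2ccoc2)c(OCC2=NCCN2)c1` — 104%

Of the compounds shown here, two have been measured in a functional assay with Alpha-1A adrenergic receptor (Homo sapiens) as the target, read by calcium flux; on this read-out higher numbers stand for larger maximal responses and lower numbers for smaller maximal responses. Compound 1 reaches 101%, and compound 2 reaches 104%. Compound 2 thus shows the highest of the two numbers, but its nearest neighbour, compound 1, sits only a number 3 percentage points higher from compound 1 to compound 2 (within the scatter), so the two cannot be told apart on this read-out.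

Compound 3 `c1ccc(-c2ncc[nH]2)c(OCC2=NCCN2)c1` has not yet been measured in this assay. It differs from compound 2 in one place: 1H-imidazol-2-yl in place of furan-3-yl on an aromatic carbon. For the measured compounds named here, the only measured step that bears on this change is the exchange of one five-membered heteroaromatic ring for another at the same position, which gave a number 3 percentage points higher from compound 1 to compound 2 (within the scatter). Going by the values given here, both compounds measured so far reach about the full response of the control. On that basis no step beyond the scatter is expected in this assay for compound 3, in either direction, and the expected step is a number 4 percentage points lower from compound 2 to compound 3 (within the scatter). Compound 3 is therefore estimated to reach 100%, within a range from 82% to 115%.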

Compound 3, largest response reached (reported as maximum), in percent of the reference or control that the assay uses: 122%
Beside the measured number, compound 3's estimate is 22 percentage points below it; measured number above the stated range.
By their numbers in this assay, from the lowest: compounds 1 and 2 (each within the scatter of the next); then compound 3.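

With 1H-imidazol-2-yl in place of furan-3-yl, this assay gives a number 18 percentage points higher from compound 2 to compound 3 (beyond the scatter) and with the same ring in place of thiophen-2-yl it gives a number 21 percentage points higher from compound 1 to compound 3 (beyond the scatter) while the earlier exchange between the two other rings had stayed within the scatter, so this position on the aromatic carbon does respond to the choice of five-membered ring. Against furan-3-yl, the entering ring has the same count of heavy atoms and no net charge, but it has 2 hetero atoms instead of 1 and 1 hydrogen-bond donor instead of 0, and these differences arrive together in a single change. Nothing available here accounts for the higher maximal response.

The compounds shown do not separate the contribution of the second ring nitrogen from that of the ring hydrogen on nitrogen, a question that 1-methyl-1H-imidazol-2-yl or oxazol-2-yl would bear on directly. They also leave open whether a group outside this family of five-membered aromatic rings, such as an aminomethyl group or a carboxylic acid, would be tolerated at this position.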